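The source may hold more compounds than are shown below. What is called first, only, known or untested is meant among the compounds shown, and "the series" means these compounds.

Three compounds share one core and differ only in the group carried on an aromatic carbon. Compound 1 `CS/C=C/c1nn(C2C[C@@H](O)[C@@H](CO)O2)c(=O)[nH]c1=O` bears 2-(methylsulfanyl)ethenyl, and in a functional assay on Vero cells (Chlorocebus sabaeus) for cytotoxicity (on this read-out lower numbers stand for stronger inhibition and higher numbers for weaker inhibition), compound 1 gives 420 ug/mL. Compound 2 `O=c1[nH]c(=O)n(C2C[C@@H](O)[C@@H](CO)O2)nc1-c1ccoc1` bears furan-3-yl, and in this assay compound 2 gives 45 ug/mL, the step being a 9.3-fold lower number from compound 1 to compound 2 (0.97 log units; beyond the scatter). Compound 3 `COC(=O)/C=C/c1nn(C2C[C@@H](O)[C@@H](CO)O2)c(=O)[nH]c1=O` bears 2-(methoxycarbonyl)ethenyl. In this assay compound 3 reaches only the limit of the assay, > 500 ug/mL, so no number is known for it, as shown by the limit of > 500 ug/mL in this assay, at which 1 of the 3 values shown sits. Against compound 2 the step is an at least 11-fold higher number from compound 2 to compound 3 (1.04 log units; beyond the scatter); against compound 1 it is an at least 1.1-fold higher number from compound 1 to compound 3 (0.07 log units; that floor lies within the scatter).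

Compound 4 `O=c1[nH]c(=O)n(C2C[C@@H](O)[C@@H](CO)O2)nc1CC(F)(F)F` has not yet been measured. It differs from compound 3 by 2,2,2-trifluoroethyl in place of 2-(methoxycarbonyl)ethenyl on an aromatic carbon. Within the data shown here, the steps that bear on this change are the two ending at compound 3: the large one from compound 2 and the one from compound 1 that lies within the scatter. Of the three groups tried on that carbon, only furan-3-yl gave a number well below the limit. Compound 4 is expected to stay near the limit, so the step of an at least 1.2-fold lower number from compound 3 to compound 4 (0.09 log units; that floor lies within the scatter) is expected to be none beyond the scatter. Compound 4 is estimated at 400 ug/mL, within a range from 150 ug/mL to 600 ug/mL.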

Compound 4, concentration for 50% inhibition: > 500 ug/mL
Compound 4 was reported as a limit (the forecaster's own chance of this, stated with the estimate: 55%); middle value at least 1.2-fold (0.09 log units) from the limit.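

In this assay compound 4 gives the limit > 500 ug/mL and no number, so a second group on this carbon now ends at the top of the read-out: the limit of > 500 ug/mL in this assay, at which 2 of the 4 values shown sit. Replacing furan-3-yl with 2,2,2-trifluoroethyl gives an at least 11-fold higher number from compound 2 to compound 4 (1.04 log units; beyond the scatter) and replacing 2-(methylsulfanyl)ethenyl with it gives an at least 1.1-fold higher number from compound 1 to compound 4 (0.07 log units; that floor lies within the scatter), so this ring-free group falls with those of compound 1 and compound 3 and not with the furan-3-yl of compound 2. Among the four groups shown, only furan-3-yl, the one group with a ring, gives a number well clear of the limit, and the step from compound 3 to compound 4 cannot be read, as both entries are limits.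

The compounds shown leave open whether another ring on this carbon, such as phenyl or thiophen-3-yl, would also give a low number or whether furan-3-yl stands alone. They also leave open what a small group such as an amine or a carboxylic acid would give at this position.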